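Swapping the Hydrazone Aryl Group in a Purine-Like Series

This account rests on a few compounds, and the source may have more. Where it says the series, first, only, none or still open, it means among the compounds named here.

Measured compounds:
Compound 1 `CCCSc1nc(N/N=C/c2ccccc2Cl)c2nnn(Cc3ccccc3)c2n1` — 13800 nM
Compound 2 `CCCSc1nc(N/N=C/c2cccnc2)c2nnn(Cc3ccccc3)c2n1` — 58700 nM

Going by the values given here, in a functional assay on MCF7 cells (Homo sapiens) for antiproliferative activity, read by MTT assay, with a stated time of 72 h (on this read-out lower numbers stand for stronger inhibition and higher numbers for weaker inhibition), compound 2 gives the higher of the two numbers, and the only step measured, a 4.3-fold higher number from compound 1 to compound 2 (0.63 log units; beyond the scatter), is modest but beyond the scatter. Compound 3 `CCCSc1nc(N/N=C(\C)c2ccccc2)c2nnn(Cc3ccccc3)c2n1` carries the change (a group of 9 heavy atoms (8 carbon, 1 nitrogen; one six-membered aromatic ring of carbon only) in place of a group of 8 heavy atoms (6 carbon, 2 nitrogen; one six-membered aromatic ring with 1 hetero atom), on a nitrogen on an aromatic ring). That step bears on the same part of the molecule as the measured one, so a change of similar size in the opposite direction is expected, giving a lower number for compound 3, estimated as a 3.9-fold lower number from compound 2 to compound 3 (0.59 log units; beyond the scatter). Compound 3 is thus expected near 15000 nM, within 5000 nM to 50000 nM.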

Compound 3, half-maximal inhibitory concentration: 32100 nM
Compound 3: the middle estimate sits 2.1-fold (0.33 log units) below what was measured; measured number inside the range.
By their numbers in this assay, from the lowest: compound 1; then compounds 3 and 2 (each within the scatter of the next).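

In this assay, the step of a 1.8-fold lower number from compound 2 to compound 3 (0.26 log units; within the scatter) lies within the scatter, so at this place the group with a six-membered aromatic ring of carbon only cannot be told from the group with a hetero atom in its ring. The modest step of a 2.3-fold higher number from compound 1 to compound 3 (0.37 log units; beyond the scatter) lies beyond the scatter, and compound 1, with its chlorine-bearing group, keeps the lowest number of the three. Nothing given here explains these numbers. Going by these compounds, what the chlorine alone contributes stays open. So does how a group carrying a methoxy or an amine in place of the chlorine would read in this assay.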